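Trading an aminophenyl for a furan on a shared core

A few compounds are considered here, and "the series" means these few. Any claim that something is new, unique, unknown or untested is made for them only; others in the source may bear on it.

Of the compounds shown here, three sharing one core have been measured in a functional assay on A549 cells (Homo sapiens) for antiproliferative activity, read by MTT assay, with a stated time of 48 h; a lower number here means a stronger inhibitor, a higher number a weaker inhibitor. Compound 1 `COc1cc(-c2cccc3nc(-c4ccc(Cl)cc4)oc23)cc(OC)c1OC`, carrying 4-chlorophenyl, gives 5600 nM. Compound 2 `COc1cc(-c2cccc3nc(-c4cccc(O)c4)oc23)cc(OC)c1OC`, carrying 3-hydroxyphenyl, gives 2000 nM, the strongest result of the three. Compound 3 `COc1cc(-c2cccc3nc(-c4cccc(N)c4)oc23)cc(OC)c1OC`, carrying 3-aminophenyl, gives 4700 nM. The step of a 1.2-fold lower number from compound 1 to compound 3 (0.08 log units; within the scatter) lies within the scatter, so these two cannot be told apart and stand together at the weaker end. The step of a 2.4-fold higher number from compound 2 to compound 3 (0.37 log units; beyond the scatter) is modest but real.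

Compound 4 `COc1cc(-c2cccc3nc(-c4ccco4)oc23)cc(OC)c1OC` has not yet been measured. It has furan-2-yl in place of 3-aminophenyl on an aromatic carbon. For the measured compounds named here, no measured pair makes this exact exchange, and none tests a five-membered ring at this place, so the evidence is indirect. The three measured steps all change the group at this same carbon, and the largest, a 2.8-fold lower number from compound 1 to compound 2 (0.45 log units; beyond the scatter), is still modest. A large move is therefore not expected, and no direction is favoured beyond the scatter.

In this assay the estimated change is a 1.2-fold lower number from compound 3 to compound 4 (0.07 log units; within the scatter), which would leave the two compounds indistinguishable. Compound 4 is expected at about 4000 nM, with an estimated range of 1500 nM to 10000 nM.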

Compound 4, half-maximal inhibitory concentration: 10300 nM
Beside the measured number, compound 4's estimate is 2.6-fold (0.41 log units) below it; measured number outside the range, above it.
By their numbers in this assay, from the lowest: compound 2; then compounds 3, 1 and 4 (each within the scatter of the next, the first and the last beyond it).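

In this assay, for the compounds shown here, this is the first group at this carbon that is a five-membered aromatic ring rather than a phenyl ring, and the exchange costs activity against both phenyl groups with a 3-substituent: furan-2-yl in place of 3-aminophenyl gives a 2.2-fold higher number from compound 3 to compound 4 (0.34 log units; beyond the scatter), and furan-2-yl in place of 3-hydroxyphenyl gives a 5.2-fold higher number from compound 2 to compound 4 (0.71 log units; beyond the scatter). Against 4-chlorophenyl, however, the same ring gives a 1.8-fold higher number from compound 1 to compound 4 (0.26 log units; within the scatter), so these two compounds cannot be told apart, and a phenyl ring at this carbon does not by itself give a lower number than furan-2-yl. No measurement shown here offers an explanation for these differences.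

Furan-2-yl differs from 3-aminophenyl in ring size, heavy-atom count and hydrogen-bond donor count all at once, so the compounds shown cannot say which of these changes matters. Unsubstituted phenyl and pyrrol-2-yl at this same carbon would help to separate them, the first by keeping the six-membered ring without an amino or hydroxy group, the second by keeping a five-membered ring with a ring nitrogen-bound hydrogen.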